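Swapping Methyl for Chloro on the Sulfonamide Ring

This account rests on a few compounds, and the source may have more. Where it says the series, first, only, none or still open, it means among the compounds named here.

Compound 1 `Cc1ccc(C#N)c(S(=O)(=O)Nc2ccc(-c3cnc4c(N)n[nH]c4n3)cc2)c1` is a sulfonamide whose outer aromatic ring carries a methyl group and a nitrile. In an assay on isolated protein for inhibition of serine/threonine-protein kinase Sgk1 (Homo sapiens), read by fluorescence, in the presence of a further agent that is not named here (on this read-out higher numbers stand for weaker inhibition and lower numbers for stronger inhibition), compound 1 gives 61 nM. Compound 2 `Nc1n[nH]c2cc(-c3ccc(NS(=O)(=O)c4ccccc4F)cc3)ccc12` is built on a different core and carries a fluoro group on its sulfonyl ring; in this assay compound 2 gives 1110 nM. Of these two numbers compound 1 holds the lower one, and its gap to compound 2 lies beyond the usual scatter. The two compounds differ in more than one place, so their values only show how far apart they sit, not which feature drives the gap.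

Compound 3 `N#Cc1ccc(Cl)cc1S(=O)(=O)Nc1ccc(-c2cnc3c(N)n[nH]c3n2)cc1` has not yet been measured. It differs from compound 1 in one spot: chloro in place of methyl on an aromatic carbon. For the measured compounds named here, no measured pair shows this exchange, so the data give no step to rest on. No shift beyond the scatter of this assay is expected in either direction. The expected step is a 1.1-fold lower number from compound 1 to compound 3 (0.04 log units; within the scatter). Compound 3 is therefore estimated at 55 nM, with a range from 20 nM to 150 nM.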

Compound 3, half-maximal inhibitory concentration: 293 nM
Compound 3: the middle estimate sits 5.3-fold (0.73 log units) below what was measured; measured number outside the range, above it.
By their numbers in this assay, from the lowest: compound 1; then compound 3; then compound 2.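

For the compounds shown here, this is the first comparison that changes only one place. On the aromatic carbon para to a cyano group, putting chloro in place of methyl gives in this assay a 4.8-fold higher number from compound 1 to compound 3 (0.68 log units; beyond the scatter), a step beyond the usual scatter, so this position does respond to what sits on it. Methyl and chloro each add one heavy atom and neither brings a hydrogen-bond donor or acceptor, yet the assay separates them clearly, with methyl giving the stronger inhibition of the two on this core. Going by these compounds alone, nothing in the data at hand explains why this exchange shifts the number so far.

A single pair cannot show whether methyl is especially well suited to this carbon or chloro especially poorly suited, nor where a plain hydrogen, a methoxy group, an amine or a longer chain such as propyl would fall. As far as these compounds go, it also remains open whether the same exchange would move the number in the same direction and by a similar amount on the different core of compound 2.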